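Pyrrolidin-1-yl in place of morpholin-4-yl on a carbonyl carbon

This account rests on a few compounds, and the source may have more. Where it says the series, first, only, none or still open, it means among the compounds named here.

Of the compounds shown here, two built on one shared core have been tested in a functional assay on A549 cells (Homo sapiens) for antiproliferative activity; a lower number here means a stronger inhibitor, a higher number a weaker inhibitor. Compound 1 `C/C=C/Cn1cc(-c2ccc(C(=O)NC3CCS(=O)(=O)CC3)c(Cl)c2)n2cncc2c1=O` gives > 10000 nM, which is a limit of the assay and not a number. Compound 2 `C/C=C/Cn1cc(-c2ccc(C(=O)N3CCOCC3)c(Cl)c2)n2cncc2c1=O` gives > 10000 nM, which is likewise only a limit. Compound 2 therefore has no exact position on the scale, and the evidence so far amounts to the limit of > 10000 nM in this assay, at which 2 of the 2 values shown sit.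

Going by the values given here, the one measured step is a step that the two limits leave unreadable from compound 1 to compound 2, so it offers no size to carry forward. It does show that the group on the carbonyl carbon was changed once without a number appearing.

Compound 3 `C/C=C/Cn1cc(-c2ccc(C(=O)N3CCCC3)c(Cl)c2)n2cncc2c1=O` makes a further change at that same place: pyrrolidin-1-yl in place of morpholin-4-yl on a carbonyl carbon. In words, pyrrolidin-1-yl stands in place of morpholin-4-yl on a carbonyl carbon. With no readable step to draw on, no shift in either direction beyond the usual scatter is expected. The estimated step is a step that the limit leaves unreadable from compound 2 to compound 3. For compound 3 the expected value is 12000 nM, with an estimated range of 5000 nM to 30000 nM.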

Compound 3, half-maximal inhibitory concentration: 8230 nM
Estimate against measurement, compound 3: 1.5-fold (0.16 log units) above; low and high end bracket the measured number.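

In this assay, going by these compounds alone, compound 3 gives 8230 nM, the first exact number for any group on this carbonyl carbon. Compound 1 and compound 2 offered only limits of the assay. Set against those limits, the swap to pyrrolidin-1-yl reads as an at least 1.2-fold lower number from compound 2 to compound 3 (0.08 log units; that floor lies within the scatter) and as an at least 1.2-fold lower number from compound 1 to compound 3 (0.08 log units; that floor lies within the scatter); each figure is only a floor, and as a floor within the scatter it does not by itself establish a real gain, though the true steps could be larger. This position can therefore yield a readable number with a ring amide that carries no oxygen, yet the series as a whole still sits at the edge of the measurable range: the limit of > 10000 nM in this assay, at which 2 of the 3 values shown sit.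

The swap from morpholin-4-yl to pyrrolidin-1-yl alters ring size and removes the ring oxygen in one move, so the compounds shown cannot tell these two changes apart, and piperidin-1-yl on the same carbonyl carbon would separate them. On these data alone, whether an open-chain amine such as dimethylamino at this place, or any other change to the shared core, could bring the number far lower also remains open.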